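Swapping a furan amide for a bromophenyl amide

The source may hold more compounds than are shown below. What is called first, only, known or untested is meant among the compounds shown, and "the series" means these compounds.

The measured compounds and their values:
compound 1, `COc1ccc(-c2cnc(NC(=O)c3ccco3)n2C)cc1`: > 100000 nM
compound 2, `Cc1ccc(C(=O)Nc2ncc(-c3ccccc3)o2)cc1`: 26000 nM
compound 3, `CCCCn1c(-c2ccc(OC)cc2)cnc1NC(=O)c1ccc(F)cc1`: > 100000 nM

All three were tested in a toxicity assay on THP-1 cells (Homo sapiens) for inhibition; a higher number here means that more compound is tolerated, a lower number that less compound is tolerated. Compound 1 returns only a limit in this assay, > 100000 nM, and not a number. Compound 3 likewise sits at a limit, > 100000 nM. Compound 2, whose core differs from the other two, gives a number in this assay, 26000 nM. Compound 1 therefore stands at the top of what the assay reports, a position it shares with one other compound; this is summed up by the limit of > 100000 nM in this assay, at which 2 of the 3 values shown sit.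

The unmeasured compound is compound 4, `COc1ccc(-c2cnc(NC(=O)c3cccc(Br)c3)n2C)cc1`. It differs from compound 1 in one place, (3-bromophenyl in place of furan-2-yl on a carbonyl carbon). Within the data shown here, no measured pair in this set differs in one place, so no directly measured step is available to guide the expectation.

The expectation for compound 4 is that the change from compound 1 brings it only slightly below the limit, a step of an at least 1.6-fold lower number from compound 1 to compound 4 (0.22 log units; that floor lies within the scatter), which may not exceed the usual scatter. Compound 4 is accordingly estimated at 60000 nM, with a range from 15000 nM to 100000 nM, and a fair chance that the assay again reports only a limit.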

Compound 4, half-maximal cytotoxic concentration: > 100000 nM
Compound 4: a limit, no number; the forecaster's own chance of this, stated with the estimate: 45%; at least 1.6-fold (0.22 log units) between middle value and limit.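

Compound 4 also returns only a limit in this assay, > 100000 nM, and not a number. Compound 1 sits at a limit as well, so the step between compound 1 and compound 4 cannot be read. The compounds shown leave open what number either would give, and so whether replacing furan-2-yl with 3-bromophenyl changes how much compound is tolerated.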